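A few compounds are considered here, and "the series" means these few. Any claim that something is new, unique, unknown or untested is made for them only; others in the source may bear on it.

In a functional assay on K562 cells (Homo sapiens) for inhibition, read by trypan blue exclusion, with a stated time of 48 h (a higher number here means a weaker inhibitor, a lower number a stronger inhibitor), none of the three measured compounds yields a number. Compound 1 (`Cc1cccc(/C=C/C(=O)Nc2ccc(Cl)cc2C(N)=O)c1`) gives > 10000 nM, which is a limit of the assay. Compound 2 (`NC(=O)c1cc(Br)ccc1NC(=O)/C=C/c1ccc(Cl)cc1`) gives > 10000 nM, again a limit. Compound 3 (`Cc1ccccc1/C=C/C(=O)Nc1ccc(Br)cc1C(N)=O`) gives > 10000 nM, also a limit. Compound 3 thus stands with the other two at the limit of > 10000 nM in this assay, at which 3 of the 3 values shown sit.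

Compound 4 (`Cc1cccc(/C=C/C(=O)Nc2ccc(Br)cc2C(N)=O)c1`) differs from compound 3 by 3-methylphenyl in place of 2-methylphenyl on a double-bonded chain carbon bound to a double-bonded chain carbon, with 3-methylphenyl in place of 2-methylphenyl on a double-bonded chain carbon bound to a double-bonded chain carbon. Among the measured compounds shown here, the only measured step that bears on this change is a step that the two limits leave unreadable from compound 2 to compound 3, so it offers no size to carry over. Compound 1 carries the same 3-methylphenyl group and gives > 10000 nM, once more a limit. No clear step in either direction is therefore expected in this assay. The estimated step is a step that the limit leaves unreadable from compound 3 to compound 4, and it remains only an expectation. For compound 4 the expected value is 12000 nM, within an estimated range of 3000 nM to 30000 nM.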

Compound 4, half-maximal inhibitory concentration: > 10000 nM
Compound 4: only a limit was reported; the forecaster's own chance of this, stated with the estimate: 75%; the middle value does not contradict the limit.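

In this assay compound 4 gives > 10000 nM, which is a limit. Its steps from compound 1, compound 2 and compound 3 cannot be read. The compounds shown leave open which change to the shared core, if any, would give a measurable value in this assay.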